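The compounds below may be only part of what the source reports. "The series", "measured", "known", "first", "only" and "open" are said of these compounds alone.

Three compounds built on one shared core have been examined in an ADME assay on BJ cells (Homo sapiens) for inhibition, with a stated time of 72 h; on this read-out lower numbers stand for an effect already at smaller amounts and higher numbers for an effect only at larger amounts of compound. Compound 1 `C=CC(=O)Nc1cccc(-c2nc3ccccc3s2)c1` gives only a limit of the assay, > 25000 nM. Compound 2 `C=C(C)C(=O)Nc1cccc(-c2nc3ccccc3s2)c1` likewise reaches only a limit, > 25000 nM. Compound 3 `CN(C)CCC(=O)Nc1cccc(-c2nc3ccccc3s2)c1` also stops at a limit, > 25000 nM. Because all three results sit at the limit of > 25000 nM in this assay, at which 3 of the 3 values shown sit, none of the steps among them can be read: a step that the two limits leave unreadable from compound 1 to compound 2, a step that the two limits leave unreadable from compound 1 to compound 3 and a step that the two limits leave unreadable from compound 2 to compound 3 each remain of unknown size. Compound 3 therefore stands where the other two stand, at the limit, with no number beneath it.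

Compound 4 `O=C(CCl)Nc1cccc(-c2nc3ccccc3s2)c1` has not yet been tested. It differs from compound 3 in one place: chloro in place of (dimethylamino)methyl on a saturated chain carbon bound to a carbonyl carbon. Among the compounds with values here, the three unreadable steps offer no size to carry over, and this particular change has no measured counterpart. On that footing the step of an at least 1.2-fold lower number from compound 3 to compound 4 (0.09 log units; that floor lies within the scatter) is expected to be small, if any. Compound 4 is estimated at 20000 nM, within a range from 3000 nM to 60000 nM, with a real chance that the assay again reports only a limit.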

Compound 4, half-maximal effective concentration: 8500 nM
Estimate against measurement, compound 4: 2.4-fold (0.37 log units) above, within the range that was stated.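

In this assay, within the data shown here, chloromethyl on the carbonyl carbon is the first group here to give a measured number rather than a limit: the limit of > 25000 nM in this assay, at which 3 of the 4 values shown sit. Chloro in place of (dimethylamino)methyl on a saturated chain carbon bound to a carbonyl carbon gives an at least 2.9-fold lower number from compound 3 to compound 4 (0.46 log units; beyond the scatter), chloromethyl in place of 1-methylethenyl gives an at least 2.9-fold lower number from compound 2 to compound 4 (0.46 log units; beyond the scatter), and chloromethyl in place of vinyl gives an at least 2.9-fold lower number from compound 1 to compound 4 (0.46 log units; beyond the scatter). Among these compounds, each step starts from a limit, so its true size may be larger, but together they show that a change at this position can move the read-out, which the earlier compounds could not show.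

The steps among compound 1, compound 2 and compound 3 still cannot be read. On these data alone, it also remains open whether the chlorine itself matters, which a plain methyl, a bromomethyl or a longer chloroalkyl chain in the same place could help to settle.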